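Aryl Variation on the Triazole Nitrogen and Compound 4

The compounds below may be only part of what the source reports. "The series", "measured", "known", "first", "only" and "open" are said of these compounds alone.

Compound 1 `CCc1ccccc1-n1nncc1CN1C(=O)C2(C(C#N)=C(N)Oc3c(N)cc4nc5ccccc5nc4c32)c2ccccc21` gives 10300 nM in a functional assay on HCT-116 cells (Homo sapiens) for antiproliferative activity, read by MTT assay, with a stated time of 48 h; on this read-out lower numbers stand for stronger inhibition and higher numbers for weaker inhibition.
Compound 2 `COc1ccc(-n2nncc2CN2C(=O)C3(C(C#N)=C(N)Oc4c(N)cc5nc6ccccc6nc5c43)c3ccccc32)cc1` gives > 50000 nM in this assay, which is a limit of the assay and not a number.
Compound 3 `N#CC1=C(N)Oc2c(N)cc3nc4ccccc4nc3c2C12C(=O)N(Cc1cnnn1-c1c(F)cccc1F)c1ccccc12` gives > 50000 nM in this assay, likewise a limit of the assay.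

Compound 3 therefore stands at the edge of what this assay reports, and it shares that position with compound 2 (the limit of > 50000 nM in this assay, at which 2 of the 3 values shown sit). Compound 1 is the only one of the three that returns a number; from it the two limit compounds are reached by an at least 4.8-fold higher number from compound 1 to compound 2 (0.68 log units; beyond the scatter) and by an at least 4.8-fold higher number from compound 1 to compound 3 (0.68 log units; beyond the scatter), while a step that the two limits leave unreadable from compound 2 to compound 3 cannot be sized. The change to compound 4 `Cc1cc(C)c(-n2nncc2CN2C(=O)C3(C(C#N)=C(N)Oc4c(N)cc5nc6ccccc6nc5c43)c3ccccc32)c(C)c1` is 2,4,6-trimethylphenyl in place of 2,6-difluorophenyl on an aromatic nitrogen. Among the measured compounds shown here, no measured step joins two compounds that both carry a number, so the direction of this step is guided only by compound 1, whose 2-ethylphenyl gave 10300 nM. Compound 3 itself returns only a limit. Compound 4 is estimated at 35000 nM, within 10000 nM to 100000 nM. That estimate means an expected at least 1.4-fold lower number from compound 3 to compound 4 (0.15 log units; that floor lies within the scatter), with a real chance that only a limit is reported again.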

Compound 4, half-maximal inhibitory concentration: > 50000 nM
Compound 4: only a limit was reported; the forecaster's own chance of this, stated with the estimate: 45%; at least 1.4-fold (0.15 log units) between middle value and limit.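

In this assay, a third aryl group on this aromatic nitrogen, 2,4,6-trimethylphenyl, also ends at the limit of the assay, and that limit now holds most of the set: the limit of > 50000 nM in this assay, at which 3 of the 4 values shown sit. Among the compounds shown here, the one readable step is an at least 4.8-fold higher number from compound 1 to compound 4 (0.68 log units; beyond the scatter), which shows that carbon-only substitution on the phenyl ring does not by itself keep a measurable value, since compound 4 carries only methyl groups there and compound 1 only an ethyl group. The steps among compound 2, compound 3 and compound 4 cannot be read, so these three aryl groups cannot be ranked against one another.

For the compounds shown here, compound 1 remains the only compound with a number, and it is open whether an unsubstituted phenyl or a 2-propylphenyl group here would also return one. On these data alone, how far compound 2, compound 3 and compound 4 lie beyond the limit also remains open.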